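The source may hold more compounds than are shown below. What is called first, only, known or untested is meant among the compounds shown, and "the series" means these compounds.

Measured so far in an ADME assay on 184B5 cells (Homo sapiens) for cytotoxicity, read by MTT assay, with a stated time of 72 h; on this read-out higher numbers stand for weaker inhibition of growth and lower numbers for stronger inhibition of growth:
Compound 1 `CCCCOC(=O)Nc1ccc([Se]C#N)cc1` gives 14500 nM.
Compound 2 `Cc1ccc(OC(=O)Nc2ccc([Se]C#N)cc2)cc1` gives 8700 nM.
Compound 3 `CCOC(=O)Nc1ccc([Se]C#N)cc1` gives 18600 nM.

Compound 3 carries the highest number of the three in this assay, which on this read-out means the weakest inhibition of growth. Within the data shown here, its nearest neighbour is compound 1, and the only step recorded between two measured compounds, a 1.3-fold higher number from compound 1 to compound 3 (0.11 log units; within the scatter), stays within the scatter. Compound 2 lies further away: compound 3 sits at 18600 nM, whereas compound 2, which carries an aromatic ring on the oxygen next to the carbonyl group, sits at 8700 nM, a gap beyond the scatter.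

Compound 4 `N#C[Se]c1ccc(NC(=O)Oc2ccccc2)cc1` follows from compound 3 by phenyl in place of ethyl on an oxygen next to a carbonyl group. The recorded step a 1.3-fold higher number from compound 1 to compound 3 (0.11 log units; within the scatter) only shortens the chain on that oxygen and is within the scatter, so it says little about exchanging a chain for a ring. The closest guide is compound 2, whose ring on that oxygen goes with a lower number than compound 3. A move toward compound 2 is therefore expected, with the step from compound 3 to compound 4 estimated at a 1.9-fold lower number from compound 3 to compound 4 (0.27 log units; within the scatter). Compound 4 is accordingly estimated at 10000 nM, with an expected range from 5000 nM to 20000 nM.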

Compound 4, concentration for total growth inhibition: 22700 nM
Compound 4: middle estimate off by 2.3-fold (0.36 log units), on the low side; the measured number lies above the stated range.
By their numbers in this assay, from the lowest: compounds 2, 1, 3 and 4 (each within the scatter of the next, the first and the last beyond it).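

In this assay, phenyl in place of ethyl gives a 1.2-fold higher number from compound 3 to compound 4 (0.09 log units; within the scatter) and phenyl in place of butyl gives a 1.6-fold higher number from compound 1 to compound 4 (0.19 log units; within the scatter), so on an oxygen next to a carbonyl group an unsubstituted phenyl cannot be told apart from either chain. The methyl on the ring of compound 2 does separate the two aryl compounds, since hydrogen in place of methyl on an aromatic carbon gives a 2.6-fold higher number from compound 2 to compound 4 (0.42 log units; beyond the scatter), a modest step beyond the scatter, and the lower number of compound 2 therefore cannot be credited to the presence of a ring alone. Nothing measured here explains why that methyl goes with stronger inhibition of growth.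

On these data alone, whether another group on that aromatic carbon, such as methoxy or chlorine, would go the same way as methyl remains open. So does whether a chain longer than butyl on that oxygen would separate from phenyl.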